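This account rests on a few compounds, and the source may have more. Where it says the series, first, only, none or still open, it means among the compounds named here.

Measured compounds and their values:
- compound 1, `CC(=O)c1ccc(OCc2ccc([N+](=O)[O-])cc2)cc1`, in an assay on isolated protein for inhibition of Amine oxidase [flavin-containing] B (Homo sapiens), read by Amplex Red, with a stated time of 15 min (a higher number here means a weaker inhibitor, a lower number a stronger inhibitor), gives 96.5 nM
- compound 2, `CC(=O)c1ccc(OCc2cccc(F)c2)cc1`, in this assay gives 83.1 nM
- compound 3, `CC(=O)c1ccc(OCc2ccc(F)c(F)c2)cc1`, in this assay gives 67.9 nM

All three share the same core and differ only in the groups carried on the outer ring. Compound 3 gives the smallest of the three numbers, yet neither compound 2 nor compound 1 is separated from it by more than the usual scatter of repeated measurements, so no real order among the three can be claimed.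

Compound 4, `CC(=O)c1ccc(OCc2cc(F)c(F)c(F)c2)cc1`, has not yet been measured. Its difference from compound 3 is a single change: fluoro in place of hydrogen on an aromatic carbon.

Among the compounds with values here, one measured step bears on this change, a 1.2-fold lower number from compound 2 to compound 3 (0.09 log units; within the scatter), which is also a fluoro in place of hydrogen on the same outer ring. That step did not move the number beyond the scatter. Within the data shown here, only this one comparison exists, so the expectation rests on it alone. Compound 4 is therefore expected to give a number close to that of compound 3, with a small downward shift if any, a 1.2-fold lower number from compound 3 to compound 4 (0.09 log units; within the scatter). The estimated value for compound 4 in this assay is 55 nM, with a range from 25 nM to 130 nM.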

Compound 4, half-maximal inhibitory concentration: 84.1 nM
Beside the measured number, compound 4's estimate is 1.5-fold (0.18 log units) below it; low and high end bracket the measured number.
By their numbers in this assay, from the lowest: compounds 3, 2, 4 and 1 (each within the scatter of the next).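

In this assay, one more fluoro in place of hydrogen, on an aromatic carbon ortho to a fluoro group and meta to a large group, gives a 1.2-fold higher number from compound 3 to compound 4 (0.09 log units; within the scatter). The earlier fluoro step gave a 1.2-fold lower number from compound 2 to compound 3 (0.09 log units; within the scatter), so the two steps are printed in opposite directions, but both lie within the scatter and together show no trend with the number of fluoro groups on the outer ring. This position therefore takes a fluoro with no shift that can be told apart from the noise of repeated measurements, and nothing at hand explains why the number stays put.

As far as these compounds go, it remains open whether a different group at this same position, such as a methoxy group, an amine or a carboxylic acid, would move the number beyond the scatter. From the compounds shown here alone, it is also open whether a trifluoromethyl group or a longer chain on the outer ring would do so, or whether a change to the shared core would matter more than any of these changes on the outer ring.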